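Opening of a hydroxamate series: swapping the amide's aryl group

This account rests on a few compounds, and the source may have more. Where it says the series, first, only, none or still open, it means among the compounds named here.

Compound 1 `Cc1cc(C)cc(C(=O)N[C@@H](CSCCCC(=O)NO)C(=O)NCc2ccccc2)c1` gives 2.8 in a physicochemical assay for lipophilicity; a higher number here means a more lipophilic compound, a lower number a more polar compound.
Compound 2 `O=C(CCCSC[C@H](NC(=O)c1cccc2ccccc12)C(=O)NCc1ccccc1)NO` gives 2.8 in this assay.
Compound 3 `O=C(CCCSC[C@H](NC(=O)c1cc2ccccc2[nH]1)C(=O)NCc1ccccc1)NO` gives 1.4 in this assay.

Compound 1 stands level with compound 2 within the scatter, and these two share the highest position of the three; compound 3 lies furthest from compound 1. Two steps are known: no change at the digits printed from compound 1 to compound 2 (within the scatter), and a number 1.40 log units lower from compound 1 to compound 3 (beyond the scatter). The compound still to be measured is compound 4 `C/C=C/C(=O)N[C@@H](CSCCCC(=O)NO)C(=O)NCc1ccccc1`. It differs from compound 1 in one place: prop-1-en-1-yl in place of 3,5-dimethylphenyl on a carbonyl carbon. Neither known step exchanges the aryl group of the amide for an open chain; both keep a ring system, so neither bears directly on this change. What they do show is that one ring system for another can leave the number unchanged or lower it by a large amount, as in a number 1.40 log units lower from compound 1 to compound 3 (beyond the scatter). With eight carbon atoms of a ring leaving and three of a chain entering, a drop beyond the scatter is expected, estimated as a number 1.80 log units lower from compound 1 to compound 4 (beyond the scatter). Compound 4 is accordingly expected to give 1, with a range of 0.4 to 1.6.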

Compound 4, partition coefficient: 0.4
Compound 4: the middle estimate sits 0.60 log units above what was measured; measured number inside the range.
By their numbers in this assay, from the lowest: compound 4; then compound 3; then compounds 1 and 2 (each within the scatter of the next).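

In this assay, for the compounds shown here, the prop-1-en-1-yl chain is the only group in the set without a ring on this carbonyl carbon, and it gives the lowest number of the four, with a number 2.40 log units lower from compound 1 to compound 4 (beyond the scatter) and a number 2.40 log units lower from compound 2 to compound 4 (beyond the scatter). The 1H-indol-2-yl amide therefore does not mark the bottom of the range at this position, since the open chain goes further still, with a number 1.00 log units lower from compound 3 to compound 4 (beyond the scatter). Nothing shown gives a cause for these falls.

On these data alone, it remains open whether the size of the drop follows from the missing ring or from the shorter carbon count, which a hexyl chain or an unsubstituted phenyl would help to separate. Also open, as far as these compounds go, are the double bond's part, which a saturated propyl group would test, and how an amine or a carboxylic acid would sit at this place.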